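Replacing Dimethylamino with Methyl on an Arylidene Thiazolidinone

This account rests on a few compounds, and the source may have more. Where it says the series, first, only, none or still open, it means among the compounds named here.

Measured compounds:
- compound 2, `CN(C)c1ccc(/C=C2\S/C(=N\c3nc(-c4ccc(Cl)cc4)cs3)NC2=O)cc1`: 300 nM
- compound 1, `COc1cccc(N2C(=O)CS/C2=N\c2csc(C3CC=Cc4ccccc43)c2C2CC=Cc3ccccc32)c1`: "not determined" (no result reported)

In a functional assay on MDA-MB-231 cells (Homo sapiens) for cytotoxicity, read by MTT assay, with a stated time of 72 h (on this read-out lower numbers stand for stronger inhibition and higher numbers for weaker inhibition), compound 2 gives 300 nM, the only number shown in the set. In this assay compound 1 gives "not determined" (no result reported). Compound 3, `Cc1ccc(/C=C2\S/C(=N\c3nc(-c4ccc(Cl)cc4)cs3)NC2=O)cc1`, differs from compound 2 in one place: methyl in place of dimethylamino on an aromatic carbon. Within the data shown here, no measured pair shows this change, so its size is not known from the data. A step of modest size toward weaker inhibition, or none beyond the usual scatter, is expected, amounting to a 2.0-fold higher number from compound 2 to compound 3 (0.30 log units; within the scatter). Compound 3 is therefore estimated at 600 nM in this assay, with a range from 150 nM to 3000 nM.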

Compound 3, half-maximal inhibitory concentration: 800 nM
For compound 3 the middle estimate is 1.3-fold (0.12 log units) below the measured one; low and high end bracket the measured number.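

In this assay, exchanging 4-(dimethylamino)phenyl for 4-methylphenyl gives a 2.7-fold higher number from compound 2 to compound 3 (0.43 log units; beyond the scatter), so this position responds to the change by a modest margin. Losing dimethylamino does not abolish inhibition, since compound 3 still gives 800 nM. Nothing available here accounts for the shift. The compounds shown leave open whether a primary amine, a methoxy group or a chlorine at this place would fall nearer compound 2 or compound 3. This single step also cannot tell whether the same exchange would act alike on another core.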